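A few compounds are considered here, and "the series" means these few. Any claim that something is new, unique, unknown or untested is made for them only; others in the source may bear on it.

Of the compounds shown here, three have been measured in a functional assay on MDA-MB-435 cells (Homo sapiens) for antiproliferative activity, read by sulforhodamine B assay, with a stated time of 48 h; on this read-out higher numbers stand for weaker inhibition and lower numbers for stronger inhibition. Compound 1 `Nc1cccc2c(-c3cccc(NC(=O)c4ccc(Cl)c(C(F)(F)F)c4)c3)ccnc12` gives 2900 nM in this assay. Compound 2 `Nc1cccc2c(-c3cccc(NC(=O)c4nccs4)c3)ccnc12` gives 1700 nM. Compound 3 `COc1ccc(C(=O)Nc2cccc(-c3ccnc4c(NC(C)=O)cccc34)c2)cc1OC` gives 270 nM, the lowest number of the three, with its distance to compound 2 and to compound 1 both beyond the usual scatter, so compound 3 stands as the strongest of the measured set.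

Compound 4 `CC(=O)Nc1cccc2c(-c3cccc(NC(=O)c4ccc(Cl)c(C(F)(F)F)c4)c3)ccnc12` has not yet been measured. It differs from compound 3 in one place: 4-chloro-3-(trifluoromethyl)phenyl in place of 3,4-dimethoxyphenyl on a carbonyl carbon. Among the measured compounds shown here, no measured pair shows this exact exchange on a shared core, so its effect is open. Compound 1 carries the same 4-chloro-3-(trifluoromethyl)phenyl group on an amino-bearing core and gives 2900 nM, a weaker number than compound 3, but the core also differs there, so that comparison cannot be read directly.

For compound 4 the expectation is a step toward weaker inhibition, a 3.3-fold higher number from compound 3 to compound 4 (0.52 log units; beyond the scatter), of moderate size and uncertain. Compound 4 is therefore estimated at 900 nM, with a range from 200 nM to 4000 nM.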

Compound 4, half-maximal inhibitory concentration: 2700 nM
Compound 4: middle estimate off by 3.0-fold (0.48 log units), on the low side; the measured number falls inside the stated range.
By their numbers in this assay, from the lowest: compound 3; then compounds 2, 4 and 1 (each within the scatter of the next).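

In this assay, putting 4-chloro-3-(trifluoromethyl)phenyl in place of 3,4-dimethoxyphenyl on the carbonyl carbon, with the rest of the molecule unchanged, gives a 10-fold higher number from compound 3 to compound 4 (1.00 log units; beyond the scatter), the first direct sign that the group at this position matters. With 4-chloro-3-(trifluoromethyl)phenyl held constant, acetyl in place of hydrogen on the nitrogen on the aromatic ring gives a 1.1-fold lower number from compound 1 to compound 4 (0.03 log units; within the scatter), so for this pair the acetyl makes no difference that can be told from the scatter. Nothing available explains the size of the step on the carbonyl carbon.

As far as these compounds go, whether the acetyl and the free amine also match when 3,4-dimethoxyphenyl sits on the carbonyl carbon remains open. So does whether an unsubstituted phenyl or a phenyl with a single methoxy group there would behave more like compound 3 or compound 4.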